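The source may hold more compounds than are shown below. What is called first, only, known or untested is meant among the compounds shown, and "the series" means these compounds.

Measured in a functional assay on cells (Neutrophil, Homo sapiens) for inhibition, with a stated time of 10 min; on this read-out higher numbers stand for weaker inhibition and lower numbers for stronger inhibition:
- compound 1 `CCOC(=O)c1cnn(CC(C)O)c1NC(=O)Nc1ccc(F)cc1`: 0.2 nM
- compound 2 `CCOC(=O)c1cnn(CC(C)O)c1NC(=O)NCc1ccccc1`: 0.00054 nM
- compound 3 `CCOC(=O)c1cnn(CC(C)O)c1NC(=O)Nc1ccccc1F`: 0.00055 nM

Compound 2 belongs to the low end of these numbers, which is the strong-inhibition end. It stands level with compound 3, as a 1.0-fold higher number from compound 2 to compound 3 (0.01 log units; within the scatter) shows, and compound 1 lies far above both.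

The new compound 4 `CCCC(O)Cn1ncc(C(=O)OCC)c1NC(=O)NCc1ccccc1` keeps the benzyl group of compound 2 and changes one thing, turning 2-hydroxypropyl into 2-hydroxypentyl: ethyl in place of hydrogen on a saturated chain carbon, two bonds along the chain from an oxygen on a saturated carbon. Within the data shown here, no measured pair changes this chain. Among the measured compounds shown here, all the measured steps concern the group on an amide-type nitrogen. Two of them are large, a 370-fold lower number from compound 1 to compound 2 (2.57 log units; beyond the scatter) and a 360-fold lower number from compound 1 to compound 3 (2.56 log units; beyond the scatter), so a single change can move this assay a long way in this small set. They still say nothing direct about the added ethyl, so neither the size nor the direction of the step is firmly grounded. Compound 2 already sits very low at 0.00054 nM, so a rise seems somewhat more likely than a further fall, and the range must stay wide.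

The expected step is a 3.7-fold higher number from compound 2 to compound 4 (0.57 log units; beyond the scatter).

For compound 4 the estimated value is 0.002 nM, with an expected range from 0.0003 nM to 0.05 nM.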

Compound 4, half-maximal inhibitory concentration: 0.0032 nM
For compound 4 the middle estimate is 1.6-fold (0.20 log units) below the measured one; low and high end bracket the measured number.
By their numbers in this assay, from the lowest: compounds 2 and 3 (each within the scatter of the next); then compound 4; then compound 1.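

With the benzyl group held fixed, the change from 2-hydroxypropyl to 2-hydroxypentyl gives a 5.9-fold higher number from compound 2 to compound 4 (0.77 log units; beyond the scatter) in this assay, so this chain is a second place, apart from the group on the amide-type nitrogen, where one change moves the number beyond the scatter. The direction is towards weaker inhibition, yet compound 4 still reads 0.0032 nM, so the added ethyl lowers inhibition without abolishing it. This step is also far smaller than the large steps seen on the amide-type nitrogen, which suggests that, in this one pair, a saturated chain carbon two bonds along the chain from an oxygen on a saturated carbon can carry an ethyl with only a modest shift.

From the compounds shown here alone, it remains open whether a shorter chain, a still longer chain, or an amine or carboxylic acid in place of the hydroxyl would raise or lower the number, and whether the same ethyl would shift it equally with the 2-fluorophenyl group of compound 3. Nothing given here accounts for the rise seen with the ethyl.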